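Trading the triazolyl chain for a dihydroxypropyl amide

This account rests on a few compounds, and the source may have more. Where it says the series, first, only, none or still open, it means among the compounds named here.

In a functional assay on HCT-116 cells (Homo sapiens) for antiproliferative activity, read by sulforhodamine B assay, with a stated time of 72 h (on this read-out higher numbers stand for weaker inhibition and lower numbers for stronger inhibition), compound 1 `Cn1ncc(Cl)c1-c1cc(C(=O)N[C@@H]2CN[C@H](CCn3cncn3)C[C@H]2c2ccc(Cl)c(Cl)c2)oc1Cl` gives 560 nM and compound 2 `Cn1ncc(Cl)c1-c1cc(C(=O)N[C@@H]2CN[C@H](CCO)C[C@H]2c2ccc(F)c(F)c2)oc1Cl` gives 360 nM so these two numbers stand within the scatter of each other and compound 1 cannot be ranked against compound 2. Compound 3 `Cn1ncc(Cl)c1-c1cc(C(=O)N[C@@H]2CN[C@H](CC(=O)NCC(O)CO)C[C@H]2c2ccc(Cl)c(Cl)c2)oc1Cl` keeps the core of compound 1 and carries (2,3-dihydroxypropyl)carbamoyl in place of (1H-1,2,4-triazol-1-yl)methyl on a saturated chain carbon bound to a saturated ring carbon. Within the data shown here, no measured step isolates this change, since compound 2 differs from compound 1 in more than one place. With a different chain, compound 2 still reads 360 nM in this assay so only a small move toward a higher number is expected, with none beyond the scatter. The estimated change is a 1.3-fold higher number from compound 1 to compound 3 (0.10 log units; within the scatter) (an expectation, not a measurement). For compound 3 the estimate is 700 nM with an expected range from 220 nM to 2000 nM (both still to be tested).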

Compound 3, half-maximal inhibitory concentration: 7090 nM
The estimate for compound 3 lay 10-fold (1.01 log units) below the measured number; the measured number lies above the stated range.
By their numbers in this assay, from the lowest: compounds 2 and 1 (each within the scatter of the next); then compound 3.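

In this assay the position on a saturated chain carbon bound to a saturated ring carbon proves sensitive to what it carries: (2,3-dihydroxypropyl)carbamoyl in place of (1H-1,2,4-triazol-1-yl)methyl gives a 13-fold higher number from compound 1 to compound 3 (1.10 log units; beyond the scatter) and so a large loss of inhibition on the core of compound 1. The read-out at this position therefore depends on the group placed there, and this ring-free group with hydroxyls and a carbonyl stands on the side of weaker inhibition. Nothing available explains this step.

On these data alone, what stays open is which feature of the entering group goes with the loss: the amide, the diol or the absence of the triazole ring. Whether a methylcarbamoyl, a carboxylic acid or a dimethylamino group on the same carbon would read nearer compound 1 or compound 3 also remains unanswered.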